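A few compounds are considered here, and "the series" means these few. Any claim that something is new, unique, unknown or untested is made for them only; others in the source may bear on it.

In a functional assay on Ehrlich cells (Mus musculus) for cytotoxicity, tested at 25 ug/mL (on this read-out higher numbers stand for a stronger effect at the one concentration tested and lower numbers for a weaker effect), compound 1 `COc1cc(N2C(N)=C(C#N)C(c3ccc([N+](=O)[O-])cc3)C3=C2CC(C)(C)CC3=O)cc(OC)c1OC` gives 50%, the highest of the three numbers recorded. Compound 2 `COc1cc(N2C(N)=C(C#N)C(/C=C/c3ccccc3)C3=C2CC(C)(C)CC3=O)cc(OC)c1OC` gives 30%, and compound 3 `COc1cc(N2C(N)=C(C#N)C(c3c(OC)ccc4ccccc34)C3=C2CC(C)(C)CC3=O)cc(OC)c1OC` gives 5%. Both measured steps away from compound 1 replace the same group on the same saturated ring carbon: a number 20 percentage points lower from compound 1 to compound 2 (beyond the scatter) and a number 45 percentage points lower from compound 1 to compound 3 (beyond the scatter). Compound 4 `COc1cc(N2C(N)=C(C#N)C(c3ccccc3O)C3=C2CC(C)(C)CC3=O)cc(OC)c1OC` differs from compound 1 in that same place: 2-hydroxyphenyl in place of 4-nitrophenyl on a saturated ring carbon. Because a number 20 percentage points lower from compound 1 to compound 2 (beyond the scatter) and a number 45 percentage points lower from compound 1 to compound 3 (beyond the scatter) both point downward, a further decrease in this assay is expected, although the two measured steps differ in size, and the step for compound 4 is estimated at a number 20 percentage points lower from compound 1 to compound 4 (beyond the scatter). Compound 4 is thus expected to give 30%, with a range from 10% to 50%.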

Compound 4, a percentage reported as activity, at one concentration (the size of the read-out at that concentration, not a potency): 0%
Estimate against measurement, compound 4: 30 percentage points above; the whole stated range lies above it.
By their numbers in this assay, from the lowest: compounds 4 and 3 (each within the scatter of the next); then compound 2; then compound 1.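

In this assay, 2-hydroxyphenyl on this saturated ring carbon gives a number 50 percentage points lower from compound 1 to compound 4 (beyond the scatter) and also a number 30 percentage points lower from compound 2 to compound 4 (beyond the scatter), so the six-membered aromatic ring that compound 4 shares with compound 1 does not by itself preserve the effect. The change to the much larger 2-methoxynaphthalen-1-yl group gives only a number 5 percentage points lower from compound 3 to compound 4 (within the scatter), leaving compound 3 and compound 4 level. No available measurement explains this loss. On these data alone, compound 4 loses the nitro group and gains the hydroxyl in one change, so the contribution of each remains open. A plain phenyl group at this carbon would separate the two.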